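Chain Length at the Aromatic Nitrogen and Agonist Potency

The compounds below may be only part of what the source reports. "The series", "measured", "known", "first", "only" and "open" are said of these compounds alone.

Compound 1, `CCCn1ncnc1-c1ccccc1NCC1=NCCN1`: in an in vitro functional assay on cells (Fibroblast) for agonist activity at Alpha-1B adrenergic receptor (Homo sapiens) (a higher number here means that more compound is needed for the effect, a lower number that less compound is needed), compound 1 gives 316 nM.
Compound 2, `CCCCn1ncnc1-c1ccccc1NCC1=NCCN1`: in this assay compound 2 gives 200 nM.
Compound 3, `Cn1cccc1-c1ccccc1NCC1=NCCN1`: in this assay compound 3 gives only a limit, < 100000 nM.

Compound 1 and compound 2 differ by methyl in place of hydrogen on a saturated chain carbon, three bonds along the chain from an aromatic nitrogen. That step gives a 1.6-fold lower number from compound 1 to compound 2 (0.20 log units; within the scatter), so the two values sit within the scatter of each other.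

Compound 4, `CCn1cccc1-c1ccccc1NCC1=NCCN1`, has not been measured in this assay. It differs from compound 3 by methyl in place of hydrogen on a saturated chain carbon bound to an aromatic nitrogen. Going by the values given here, this is the same kind of change as the one from compound 1 to compound 2, but the place differs: there the methyl enters three bonds along the chain from an aromatic nitrogen, here on a saturated chain carbon bound to an aromatic nitrogen. How the core of compound 3 differs from the core of compound 1 is not broken down here.

Since compound 3 gives only a limit (the limit of < 100000 nM in this assay, at which 1 of the 3 values shown sits), the step expected from compound 3 to compound 4 is uncertain and estimated as a step that the limit leaves unreadable from compound 3 to compound 4. For compound 4 a value of about 60000 nM is expected, between 5000 nM and 200000 nM, with a fair chance that again only a limit is reported.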

Compound 4, half-maximal effective concentration: < 100000 nM
Compound 4 gave a limit, no number (the forecaster's own chance of this, stated with the estimate: 55%); the middle value is on the limit's open side.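

In this assay compound 4 gives only a limit, as compound 3 does, so no step can be read for methyl in place of hydrogen between these two compounds: the limit of < 100000 nM in this assay, at which 2 of the 4 values shown sit.

The compounds shown leave open where the true values of compound 3 and compound 4 lie, and whether the chain on the aromatic nitrogen matters at all on their core.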